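The source may hold more compounds than are shown below. What is called first, only, known or untested is meant among the compounds shown, and "the series" means these compounds.

Working notes on the series. For the measured compounds named here, in an ADME assay on a cell-free system (plasma, Homo sapiens) for metabolic stability, with Plasma (Rattus norvegicus) as the target, read by HPLC, at pH 7.4 (on this read-out higher numbers stand for a longer-lived compound and lower numbers for a shorter-lived compound), compound 1 `CC(=O)Oc1ccccc1C(=O)O[C@H]1CO[C@H]2[C@@H]1OC[C@H]2OC(=O)c1ccccc1` gives 0.055 h; compound 2 `CC(=O)Oc1ccccc1C(=O)O[C@H]1CO[C@H]2[C@@H]1OC[C@H]2OC(=O)c1cccc(C)c1` gives 0.165 h, the higher of the two numbers so far, and the step of a 3.0-fold higher number from compound 1 to compound 2 (0.48 log units; beyond the scatter) lies beyond the scatter. Compound 3 `CC(=O)Oc1ccccc1C(=O)O[C@H]1CO[C@H]2[C@@H]1OC[C@H]2OC(=O)c1ccccc1CO[N+](=O)[O-]` is unmeasured; it differs from compound 2 by 2-((nitrooxy)methyl)phenyl in place of 3-methylphenyl on a carbonyl carbon. Going by the values given here, only the step of a 3.0-fold higher number from compound 1 to compound 2 (0.48 log units; beyond the scatter) bears on this change, and it concerns a different group on the same ring, so direction is uncertain. Compound 3 is expected to land near compound 2, with a step of a 1.2-fold higher number from compound 2 to compound 3 (0.08 log units; within the scatter) in this assay, estimated at 0.2 h within 0.06 h to 0.7 h.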

Compound 3, half-life: 0.045 h
The estimate for compound 3 lay 4.4-fold (0.65 log units) above the measured number; measured number below the stated range.
By their numbers in this assay, from the lowest: compounds 3 and 1 (each within the scatter of the next); then compound 2.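

In this assay 2-((nitrooxy)methyl)phenyl in place of 3-methylphenyl on a carbonyl carbon gives a 3.7-fold lower number from compound 2 to compound 3 (0.56 log units; beyond the scatter) and so gives up the gain seen with the methyl group. Set against hydrogen, (nitrooxy)methyl gives a 1.2-fold lower number from compound 1 to compound 3 (0.09 log units; within the scatter) and leaves the half-life where the plain phenyl ester had it. Nothing at hand accounts for this result. Still open, from the compounds shown here alone, is whether this reading is specific to (nitrooxy)methyl. An amine or a carboxylic acid on the same ring, or a longer chain ending in nitrooxy, would test that.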